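Isopropoxy to Ethoxy in a Cytotoxicity Series

A few compounds are considered here, and "the series" means these few. Any claim that something is new, unique, unknown or untested is made for them only; others in the source may bear on it.

Of the compounds shown here, three have been measured in a toxicity assay on Huh-7.5 cells (Homo sapiens) for inhibition, read by MTT assay, with a stated time of 96 h; on this read-out lower numbers stand for higher toxicity in this test and higher numbers for lower toxicity in this test. Compound 1 `COc1ccc(C(=O)Nc2ccc(N(C)C)cc2)cc1[N+](=O)[O-]` gives 88200 nM, and compound 3 `CN1CCN(Cc2ccc(NC(=O)c3ccc(OCCCl)c([N+](=O)[O-])c3)cc2C(F)(F)F)CC1` gives 9040 nM. Compound 2 `CCC(=O)Nc1cc(C(=O)Nc2ccc(OC)cc2)ccc1OC(C)C` gives 113000 nM, which lies within the scatter of compound 1 and stands higher than compound 3 by a margin beyond the scatter. Compound 4 `CCOc1ccc(C(=O)Nc2ccc(OC)cc2)cc1NC(=O)CC` differs from compound 2 by a single change, isopropoxy to ethoxy: hydrogen in place of methyl on a saturated chain carbon bound to an oxygen on an aromatic ring and a saturated chain carbon. Going by the values given here, no two measured compounds differ in only one place, so no measured step indicates the size of this change. No step beyond the scatter is expected in this assay, in either direction. The estimated step is a 1.1-fold lower number from compound 2 to compound 4 (0.05 log units; within the scatter). Compound 4 is expected at 100000 nM, with an estimated range from 50000 nM to 200000 nM.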

Compound 4, half-maximal cytotoxic concentration: 73200 nM
The estimate for compound 4 lay 1.4-fold (0.14 log units) above the measured number, and the stated range covers the measured number.
By their numbers in this assay, from the lowest: compound 3; then compounds 4, 1 and 2 (each within the scatter of the next).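

Going by these compounds alone, replacing isopropoxy with ethoxy gives a 1.5-fold lower number from compound 2 to compound 4 (0.19 log units; within the scatter) in this assay, the first measured step at this position. Losing this one methyl from the saturated chain carbon bound to the oxygen therefore does not move the number beyond the scatter in this test. Nothing available bears on why this is so.
On these data alone, whether a longer chain or a chain ending in an amine at this place would move the number beyond the scatter remains open. So does whether the isopropoxy to ethoxy change would give a similar step on another core.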